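Extending Compound 2 with an Isopentylcarbamoyl Group

The compounds below may be only part of what the source reports. "The series", "measured", "known", "first", "only" and "open" are said of these compounds alone.

In an ADME assay on HEK-293T cells (Homo sapiens) for cytotoxicity, read by luminescence, with a stated time of 24 h (on this read-out higher numbers stand for lower toxicity in this test and lower numbers for higher toxicity in this test), three compounds have been measured so far. Compound 1, `CCOC(=O)c1cc2sccc2n1Cc1ccc(OC)cc1`, gives > 100000 nM, which is a limit of the test rather than a number. Compound 2, `COc1ccc(Cn2c(C(=O)N3CCCCC3)cc3sccc32)cc1`, likewise gives > 100000 nM, again a limit and not a number. Compound 3, `CCOC(=O)C1CCN(C(=O)c2cc3sccc3n2Cc2ccc(OC)cc2)CC1`, gives 39000 nM, a number inside the measured range. The step that the two limits leave unreadable from compound 1 to compound 2 cannot be read, since both of its values are limits. The step of an at least 2.5-fold lower number from compound 2 to compound 3 (0.40 log units; beyond the scatter) is readable at one end only, because the value of compound 2 is a limit. Compound 2 therefore stands at the limit of > 100000 nM in this assay, at which 2 of the 3 values shown sit, and nothing finer than that is known of it.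

Compound 4, `COc1ccc(Cn2c(C(=O)N3CCC(C(=O)NCCC(C)C)CC3)cc3sccc32)cc1`, differs from compound 2 by isopentylcarbamoyl in place of hydrogen on a saturated ring carbon. Among the compounds with values here, the only measured step that bears on this change is an at least 2.5-fold lower number from compound 2 to compound 3 (0.40 log units; beyond the scatter), where a group also entered on a saturated ring carbon of the same ring. A step of similar direction and at least similar size is expected here, so the step of an at least 2.8-fold lower number from compound 2 to compound 4 (0.45 log units; beyond the scatter) is estimated. Compound 4 is therefore expected to give 35000 nM in this assay, with a range from 12000 nM to 100000 nM.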

Compound 4, half-maximal cytotoxic concentration: 30900 nM
Estimate against measurement, compound 4: 1.1-fold (0.05 log units) above; the measured number falls inside the stated range.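

In this assay, placing isopentylcarbamoyl on the saturated ring carbon gives an at least 3.2-fold lower number from compound 2 to compound 4 (0.51 log units; beyond the scatter); with compound 3, that makes two groups at this ring carbon that go with a number inside the measured range, while compound 2, with only hydrogen there, does not have one. Replacing ethoxy with isopentylamino on the carbonyl carbon gives a 1.3-fold lower number from compound 3 to compound 4 (0.10 log units; within the scatter), so compound 3 and compound 4 cannot be told apart in this test, and the ester and the longer amide ending serve equally well here. The true size of the step from the hydrogen-bearing ring is bounded on one side only, because compound 2 stands at a limit of the test rather than at a number: the limit of > 100000 nM in this assay, at which 2 of the 4 values shown sit.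

From the compounds shown here alone, whether a carboxylic acid or a plain amine on this ring carbon would also give a number inside the measured range remains open, as does whether a longer chain on the amide would give a different number from the isopentyl chain. The compounds shown also leave open why a group at this position goes with higher toxicity in this test.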